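Compound 3 to Compound 4: A 2-Carboxyethyl Swap

This account rests on a few compounds, and the source may have more. Where it says the series, first, only, none or still open, it means among the compounds named here.

In a functional assay on MCF7 cells (Homo sapiens) for antiproliferative activity, read by MTT assay, with a stated time of 24 h (a higher number here means a weaker inhibitor, a lower number a stronger inhibitor), compound 1 `CCn1c(C(=O)N[C@@H](C)C(=O)OC)ccc1C(CC)(CC)c1ccc(OCS(=O)(=O)c2ccccc2)c(C)c1` gives 43700 nM. Compound 3 `CCn1c(C(=O)N[C@@H](C(=O)O)C(C)C)ccc1C(CC)(CC)c1ccc(OCS(=O)(=O)c2ccccc2)c(C)c1` gives 44700 nM, which places it level with compound 1 within the scatter. Compound 2 `CCn1c(C(=O)N[C@H](C)C(=O)O)ccc1C(CC)(CC)c1ccc(OCS(=O)(=O)c2ccccc2)c(C)c1` is recorded only as a limit, > 50000 nM. Compound 4 `CCn1c(C(=O)NCCC(=O)O)ccc1C(CC)(CC)c1ccc(OCS(=O)(=O)c2ccccc2)c(C)c1` carries 2-carboxyethyl in place of 1-carboxy-2-methylpropyl on an amide-type nitrogen. Three measured changes at this nitrogen bear on it: an at least 1.1-fold higher number from compound 1 to compound 2 (0.05 log units; that floor lies within the scatter), a 1.0-fold higher number from compound 1 to compound 3 (0.01 log units; within the scatter) and an at least 1.1-fold lower number from compound 2 to compound 3 (0.04 log units; that floor lies within the scatter). None goes beyond the scatter, so no step beyond the scatter is expected in this assay. The expected change is a 1.0-fold higher number from compound 3 to compound 4 (0.01 log units; within the scatter). For compound 4 the estimate is 46000 nM, with an expected range from 28000 nM to 75000 nM.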

Compound 4, half-maximal inhibitory concentration: > 50000 nM
Compound 4 was reported as a limit; the forecaster's own chance of this, stated with the estimate: 45%; middle value at least 1.0-fold (0.03 log units) away from the limit.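

Compound 4 in this assay is a limit, the second in this set: the limit of > 50000 nM in this assay, at which 2 of the 4 values shown sit.

Replacing 1-carboxy-2-methylpropyl with 2-carboxyethyl gives an at least 1.1-fold higher number from compound 3 to compound 4 (0.04 log units; that floor lies within the scatter), and replacing 1-(methoxycarbonyl)ethyl with it gives an at least 1.1-fold higher number from compound 1 to compound 4 (0.05 log units; that floor lies within the scatter). Among these compounds, the step from compound 2 to compound 4 cannot be read, so even without a defined stereocentre at this position, the amide-type nitrogen shows no step that can be placed beyond the scatter.

As far as these compounds go, how far compound 4 lies past its limit stays open. So does whether an amine or a methyl ester on a chain at this nitrogen would give a lower number.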